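Working notes: a methyl added to compound 2

The source may hold more compounds than are shown below. What is called first, only, known or untested is meant among the compounds shown, and "the series" means these compounds.

- compound 1 `O=C(NCc1cc(-c2ccc(C(F)(F)F)nc2)ncn1)[C@@H]1CCN1S(=O)(=O)c1ccc(F)cc1` gives 27 mL/min/kg
- compound 2 `O=C(NCc1cc(-c2ccc(C(F)(F)F)nc2)ncn1)[C@@H]1CCCN1S(=O)(=O)c1ccc(F)cc1` gives 43 mL/min/kg

In an ADME assay on microsomes from liver (Rattus norvegicus) for pharmacokinetics (on this read-out higher numbers stand for fast clearance and lower numbers for slow clearance), compound 2 gives 43 mL/min/kg and lies within the scatter of compound 1, so these two measurements cannot be told apart.

The change leading to compound 3 `C[C@H]1CC[C@@H](C(=O)NCc2cc(-c3ccc(C(F)(F)F)nc3)ncn2)N1S(=O)(=O)c1ccc(F)cc1` is methyl in place of hydrogen on a saturated ring carbon and sits on a saturated ring carbon of the five-membered non-aromatic ring with 1 nitrogen, next to the ring nitrogen. Among the compounds with values here, no pair of measured compounds shows a step of this kind, so the data give no direction for it. No step beyond the scatter is expected in this assay on present evidence. The estimated change is a 1.0-fold higher number from compound 2 to compound 3 (0.02 log units; within the scatter) and stays inside the scatter. For compound 3 the estimated clearance is 45 mL/min/kg with an expected range from 24 mL/min/kg to 80 mL/min/kg in this measurement.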

Compound 3, clearance: 47 mL/min/kg
The estimate for compound 3 lay 1.0-fold (0.02 log units) below the measured number; measured number inside the range.
By their numbers in this assay, from the lowest: compounds 1, 2 and 3 (each within the scatter of the next).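

In this assay, methyl in place of hydrogen on a saturated ring carbon, next to the ring nitrogen, gives a 1.1-fold higher number from compound 2 to compound 3 (0.04 log units; within the scatter) and is the only step of this kind in the series so far. Compound 2 and compound 3 cannot be told apart on this read-out, so this place on the five-membered non-aromatic ring with 1 nitrogen takes one methyl without a clearance difference that can be read. Within the data shown here, nothing measured so far offers an explanation for this result.

On these data alone, whether a longer chain, a hydroxymethyl group or an amine at this place would give a step beyond the scatter remains open. So does whether methyl on the other saturated ring carbons, or on the smaller ring of compound 1, would read the same.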